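Amino in Place of Chloro on a Fused Ring

The source may report more compounds than this note shows. Statements on the series, on what has been measured and on what is new or still open speak of the compounds shown alone.

Going by the values given here, compound 2 `Nc1nn(C(=O)Nc2ccc(Cc3ccccc3)cc2)c2ccc(Cl)cc12` gives 2520 nM in a functional assay on A549 cells (Homo sapiens) for antiproliferative activity, read by sulforhodamine B assay, with a stated time of 48 h (a higher number here means a weaker inhibitor of growth, a lower number a stronger inhibitor of growth), the lowest of the two numbers known, while compound 1 `Nc1nn(C(=O)Nc2ccc(Cc3ccccc3)cc2)c2ccccc12` gives 12900 nM. Among the compounds with values here, the only step known, a 5.1-fold lower number from compound 1 to compound 2 (0.71 log units; beyond the scatter), shows that one small group at this position can shift the result well beyond the scatter. Compound 3 `Nc1ccc2c(c1)c(N)nn2C(=O)Nc1ccc(Cc2ccccc2)cc1` carries amino in place of chloro on an aromatic carbon. Within the data shown here, no measured step involves an amino group, so the direction is open and the chloro gain may partly recede. The expected step is a 2.4-fold higher number from compound 2 to compound 3 (0.38 log units; beyond the scatter). Compound 3 is estimated at 6000 nM, within a range of 1500 nM to 25000 nM.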

Compound 3, concentration for 50% growth inhibition: 6580 nM
Estimate against measurement, compound 3: 1.1-fold (0.04 log units) below; measured number inside the range.
By their numbers in this assay, from the lowest: compound 2; then compounds 3 and 1 (each within the scatter of the next).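

In this assay, the step of a 2.6-fold higher number from compound 2 to compound 3 (0.42 log units; beyond the scatter) shows that the gain seen with chloro on this aromatic carbon does not carry over to amino. Set against hydrogen, amino gives a 2.0-fold lower number from compound 1 to compound 3 (0.29 log units; within the scatter), so at this position the result depends on which group is present, and amino cannot be told apart from hydrogen. Nothing available explains the difference between chloro and amino. As far as these compounds go, it remains open whether bromo or methoxy on the same carbon would behave like chloro or like amino.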